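Series notes: benzyl to phenyl on the amide-type nitrogen

The source may hold more compounds than are shown below. What is called first, only, known or untested is meant among the compounds shown, and "the series" means these compounds.

Measured compounds, with their maximal responses in a functional assay on membranes from Sf9 cells for agonist activity at histamine H2 receptor (Homo sapiens), read by scintillation counting and GTPgammaS binding, with a stated time of 90 min; on this read-out lower numbers stand for smaller maximal responses and higher numbers for larger maximal responses:
compound 1 `CCCCCCNC(=O)/N=C(\N)NCCCc1sc(N)nc1C`, 0.6
compound 2 `Cc1nc(N)sc1CCCN/C(N)=N/C(=O)NCc1ccccc1`, 0.91

Within the data shown here, compound 2 stands highest of the two numbers in this assay, compound 1 being its only neighbour: the step a number 0.31 higher from compound 1 to compound 2 (beyond the scatter). Compound 3 `Cc1nc(N)sc1CCCN/C(N)=N/C(=O)Nc1ccccc1` is not yet measured. Its difference from compound 2 is phenyl in place of benzyl on an amide-type nitrogen. Among the measured compounds shown here, the one measured step, from compound 1 to compound 2, concerns a saturated chain carbon and a pentyl-for-phenyl exchange, so it bears only loosely on the present change, which sits on the amide-type nitrogen itself; it shows an aromatic group at that end of the molecule going with a large response. For compound 3 a modest fall or no step beyond the scatter is expected: the step a number 0.11 lower from compound 2 to compound 3 (beyond the scatter) is the estimate. Compound 3 is therefore expected to give about 0.8, between 0.55 and 1.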

Compound 3, intrinsic activity: the largest response reached, as a fraction of the reference agonist's: 0.59
Compound 3: the middle estimate sits 0.21 above what was measured, within the range that was stated.
By their numbers in this assay, from the lowest: compounds 3 and 1 (each within the scatter of the next); then compound 2.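

In this assay, the maximal response does not survive the exchange of benzyl for phenyl on the amide-type nitrogen (a number 0.32 lower from compound 2 to compound 3 (beyond the scatter)), so the chain carbon of the benzyl group matters at this position, a point the earlier pair could not show. An aromatic ring alone does not give the large response of compound 2: compound 3 goes against that reading, and phenyl in place of hexyl leaves the response within the scatter (a number 0.010 lower from compound 1 to compound 3 (within the scatter)). Nothing available explains why the benzyl group behaves differently from phenyl here.

From the compounds shown here alone, whether a longer link to the ring, as in 2-phenylethyl, keeps the response of compound 2 remains open. So does the effect of a fluorine or methoxy group on the benzyl ring.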